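Swapping the cyclopentenyl ring for a methylthiophene

The compounds below may be only part of what the source reports. "The series", "measured", "known", "first", "only" and "open" are said of these compounds alone.

Compound 1 `Cn1nc2c(=O)n(CC3(O)CCN(Cc4ccc(-c5ccncc5)cc4Cl)CC3)cnc2c1-c1ccc(CN)cc1`: 257 nM
Compound 2 `Cn1nc2c(=O)n(CC3(O)CCN(Cc4ccc(-c5cnco5)cc4Cl)CC3)cnc2c1-c1ccc(CN)cc1`: 71.6 nM
Compound 3 `Cn1nc2c(=O)n(CC3(O)CCN(Cc4ccc(C5=CCCC5)cc4Cl)CC3)cnc2c1-c1ccc(CN)cc1`: 76.9 nM

All three were tested in an assay on isolated protein for inhibition of ubiquitin carboxyl-terminal hydrolase 7 (Homo sapiens), with stated times of 30 min and 2 h; a higher number here means a weaker inhibitor, a lower number a stronger inhibitor. Compound 3 sits second highest of the three numbers; its value and that of compound 2 lie within the scatter, while a 3.3-fold lower number from compound 1 to compound 3 (0.52 log units; beyond the scatter) lies beyond it. Compound 4 `Cc1ccc(-c2ccc(CN3CCC(O)(Cn4cnc5c(-c6ccc(CN)cc6)n(C)nc5c4=O)CC3)c(Cl)c2)s1` differs from compound 3 in one place: 5-methylthiophen-2-yl in place of cyclopent-1-en-1-yl on an aromatic carbon. Among the compounds with values here, two measured steps bear on this: a 1.1-fold higher number from compound 2 to compound 3 (0.03 log units; within the scatter) shows a five-membered aromatic ring and the cyclopentenyl ring giving indistinguishable numbers, and a 3.6-fold lower number from compound 1 to compound 2 (0.56 log units; beyond the scatter) shows a five-membered aromatic ring beating the six-membered pyridinyl. The entering group is again a five-membered aromatic ring, so no step beyond the scatter is expected in this assay, a 1.1-fold lower number from compound 3 to compound 4 (0.04 log units; within the scatter). Compound 4 is estimated at 70 nM, between 30 nM and 170 nM.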

Compound 4, half-maximal inhibitory concentration: 101 nM
Estimate against measurement, compound 4: 1.4-fold (0.16 log units) below, and the stated range covers the measured number.
By their numbers in this assay, from the lowest: compounds 2, 3 and 4 (each within the scatter of the next); then compound 1.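

In this assay this position accepts 5-methylthiophen-2-yl, a ring carrying sulfur and a methyl group, as readily as the earlier five-membered rings: a 1.3-fold higher number from compound 3 to compound 4 (0.12 log units; within the scatter) and a 1.4-fold higher number from compound 2 to compound 4 (0.15 log units; within the scatter) both stay within the scatter. The pyridin-4-yl compound stays apart, with a 2.5-fold lower number from compound 1 to compound 4 (0.41 log units; beyond the scatter) as the step, so three five-membered rings now group together against one six-membered ring. Nothing measured here explains these numbers.

Open, as far as these compounds go, is how a plain phenyl ring would read here, which would separate ring size from the pyridine nitrogen. Also open, from the compounds shown here alone, is how an amine or a carboxylic acid on this carbon would read.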